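A Smaller Para Group on the Benzyl Ring of Compound 1

The source may hold more compounds than are shown below. What is called first, only, known or untested is meant among the compounds shown, and "the series" means these compounds.

Compound 1 `CCOC(=O)c1ccc(CO/N=C/c2c(C)nn(C)c2Oc2ccc(Cl)cc2)cc1` is the reference point here. In a functional assay on A549 cells (Homo sapiens) for antiproliferative activity, tested at 1 uM (on this read-out lower numbers stand for less inhibition and higher numbers for more inhibition at the one concentration tested (going by the name of the read-out)), compound 1 gives 48.2%, the highest of the three measured numbers. Compound 3 `Cc1nn(C)c(Oc2ccccc2)c1/C=N/OCc1ccc([N+](=O)[O-])cc1` gives 39.4%, which is within the scatter of compound 1. Compound 2 `CCOC(=O)c1ccc(CO/N=C/c2c(C)nn(-c3ccccc3)c2Oc2ccc(Cl)cc2)cc1` gives -9.9%, far below; the step of a number 58.1 percentage points lower from compound 1 to compound 2 (beyond the scatter) shows how much phenyl in place of methyl on an aromatic nitrogen cost.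

Compound 4 `COc1ccc(CO/N=C/c2c(C)nn(C)c2Oc2ccc(Cl)cc2)cc1` differs from compound 1 elsewhere: methoxy in place of ethoxycarbonyl on an aromatic carbon. Among the compounds with values here, no measured step touches this part of the molecule in a single change. The step from compound 1 to compound 2 concerns the aromatic nitrogen and does not bear on it. Compound 3 differs from compound 1 in two places, one of them a nitro group where compound 1 has its ethoxycarbonyl, and its value sits within the scatter of compound 1, so a change at this spot has not shown a large effect. The expectation is therefore a step of a number 10.2 percentage points lower from compound 1 to compound 4 (beyond the scatter), not beyond the scatter. Compound 4 is expected to give 38%, with a range from 15% to 60%.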

Compound 4, a percentage reported as inhibition, at one concentration (the size of the read-out at that concentration, not a potency): 43.9%
Estimate against measurement, compound 4: 5.9 percentage points below; low and high end bracket the measured number.
By their numbers in this assay, from the lowest: compound 2; then compounds 3, 4 and 1 (each within the scatter of the next).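

Within the data shown here, the swap of ethoxycarbonyl for methoxy, on an aromatic carbon para to a large group, is the first single change at this spot, and in this assay it gives a number 4.3 percentage points lower from compound 1 to compound 4 (within the scatter). The ethoxycarbonyl group, with its carbonyl, is therefore not required to keep this level of inhibition on the core of compound 1, something compound 3 could not show, since it differs from compound 1 in two places. No measurement at hand says what lies behind this result.

On these data alone, whether an amine, a carboxylic acid or a longer chain at this position would keep the inhibition remains open. Also open, as far as these compounds go, is whether methoxy would fare the same with phenyl on the aromatic nitrogen, the change that marks compound 2.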